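This account rests on a few compounds, and the source may have more. Where it says the series, first, only, none or still open, it means among the compounds named here.

Working notes on the series: in a functional assay on K562 cells (Homo sapiens) for inhibition, read by CCK-8 assay, with a stated time of 72 h (on this read-out lower numbers stand for stronger inhibition and higher numbers for weaker inhibition), compound 1 `O=C(/C=C/c1cccnc1)NCCCCCCc1cccc(S(=O)(=O)Nc2ccccc2)c1` gives 0.88 nM, compound 2 `Cc1ccc(NS(=O)(=O)c2cccc(CCCCCCNC(=O)/C=C/c3cccnc3)c2)cc1` gives 2.98 nM and compound 3 `O=C(/C=C/c1cccnc1)NCCCCCCc1cccc(S(=O)(=O)Nc2ccc(Cl)cc2)c1` gives 6.41 nM. Compound 3 therefore has the highest number of the three and the weakest inhibition, with its steps to both others beyond the scatter.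

The next change leads to compound 4 `O=C(/C=C/c1cccnc1)NCCCCCCc1cccc(S(=O)(=O)Nc2ccc(Oc3ccccc3)cc2)c1`, with phenoxy in place of chloro on an aromatic carbon.

Three measured steps at this carbon bear on it, all modest: a 3.4-fold higher number from compound 1 to compound 2 (0.53 log units; beyond the scatter), a 7.3-fold higher number from compound 1 to compound 3 (0.86 log units; beyond the scatter) and a 2.2-fold higher number from compound 2 to compound 3 (0.33 log units; beyond the scatter). For the measured compounds named here, each of these steps raises the number, and no compound among the three goes against that order. None of them involves phenoxy, however, so the size of the new step is poorly defined. A further modest step towards a higher number is expected in this assay. The expected change is a 2.2-fold higher number from compound 3 to compound 4 (0.34 log units; beyond the scatter). For compound 4 the estimated value is 14 nM, with an expected range from 4 nM to 50 nM.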

Compound 4, half-maximal inhibitory concentration: 5.12 nM
Compound 4: middle estimate off by 2.7-fold (0.44 log units), on the high side, and the stated range covers the measured number.
By their numbers in this assay, from the lowest: compound 1; then compounds 2, 4 and 3 (each within the scatter of the next, the first and the last beyond it).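

In this assay the seven heavy atoms of phenoxy, with their six-membered aromatic ring, replace the single chlorine atom of chloro, yet the numbers lie close together, with a 1.3-fold lower number from compound 3 to compound 4 (0.10 log units; within the scatter) and, against methyl, a 1.7-fold higher number from compound 2 to compound 4 (0.24 log units; within the scatter) both within the scatter. Against hydrogen the step is a 5.8-fold higher number from compound 1 to compound 4 (0.76 log units; beyond the scatter) and lies beyond the scatter, so at this carbon the number does not climb with the size of the group, while hydrogen still gives the lowest number of the four. No measurement at hand offers a reason for this result.

From the compounds shown here alone, whether any group at this carbon can match hydrogen stays open, an amine or a carboxylic acid being obvious cases. Also open, going by these compounds, is whether this pattern would hold with a shorter chain in the shared core.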